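The compounds below may be only part of what the source reports. "The series", "measured", "known", "first", "only" and "open" are said of these compounds alone.

Measured compounds:
- compound 1, `CC[C@H](CCCc1cccnc1)NC(=O)/C=C/C=C(c1ccc(OC)cc1)c1ccc(OC)cc1`: 6 mg/kg
- compound 2, `CCCCCCCC/C(=C\C=C\C(=O)N[C@H](C)CCCc1cccnc1)c1ccc(OC)cc1`: 13 mg/kg
- compound 3, `CC/C(=C\C=C\C(=O)N[C@H](C)CCCc1cccnc1)c1ccc(OC)cc1`: 35 mg/kg

In a functional assay on the whole organism for inhibition, with Cavia porcellus as the target, with a stated time of 2 h (a lower number here means that less compound is needed, a higher number that more compound is needed for the effect), compound 1 gives 6 mg/kg, the lowest of the three numbers; compound 2 gives 13 mg/kg and compound 3 gives 35 mg/kg, both beyond the scatter from compound 1. Compound 1 and compound 2 differ in more than one place, so their values are only set side by side.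

The unmeasured compound 4, `COc1ccc(C(=C/C=C/C(=O)N[C@@H](CCCc2cccnc2)C2CC2)c2ccc(OC)cc2)cc1`, differs from compound 1 in one place: cyclopropyl in place of ethyl on a saturated chain carbon bound to an amide-type nitrogen and a saturated chain carbon.

Going by the values given here, the only measured single step, a 2.7-fold higher number from compound 2 to compound 3 (0.43 log units; beyond the scatter), concerns a substituent on the other end of the molecule, far from the amide nitrogen, and so does not bear directly on the change from compound 1 to compound 4. Among the compounds with values here, no measured pair varies the group on the saturated chain carbon bound to the amide-type nitrogen. The change itself is small in what leaves and enters, so a step within the scatter, in either direction, is expected: no change at the digits printed from compound 1 to compound 4 (within the scatter). In this assay compound 4 is estimated at 6 mg/kg, with a range from 3 mg/kg to 14 mg/kg.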

Compound 4, dose for 50% inhibition: 6 mg/kg
Estimate against measurement, compound 4: no gap at the digits printed; the range from low to high includes it.
By their numbers in this assay, from the lowest: compounds 1 and 4 (each within the scatter of the next); then compound 2; then compound 3.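

In this assay, cyclopropyl in place of ethyl on a saturated chain carbon bound to an amide-type nitrogen and a saturated chain carbon gives no change at the digits printed from compound 1 to compound 4 (within the scatter). Going by these compounds alone, this is the first single-place reading at this position, as the earlier step, a 2.7-fold higher number from compound 2 to compound 3 (0.43 log units; beyond the scatter), concerned a different carbon; here, a three-membered non-aromatic ring of carbon only is accepted in place of ethyl without a step beyond the scatter. No measurement at hand explains this result or shows how the two groups compare in any other respect.

Going by these compounds, whether a phenyl ring, a tert-butyl group, or a chain ending in an amine or a carboxylic acid would be accepted at this position stays open. This single pair also does not show whether the same change would give a similar result on the core of compound 2.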